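Azetidine replacing benzylamine on the quinone-like carbon

This account rests on a few compounds, and the source may have more. Where it says the series, first, only, none or still open, it means among the compounds named here.

The series shares one core; compound 1 `COc1ccccc1NC1=CC(=O)c2c(nc3n2[C@H]2OC[C@@H](O)[C@H]2OC3)C1=O` carries a 2-methoxyphenylamino group, compound 2 `O=C1C(Nc2ccccc2)=CC(=O)c2c1nc1n2[C@H]2OC[C@@H](O)[C@H]2OC1` a phenylamino group, compound 3 `O=C1C(NCc2ccccc2)=CC(=O)c2c1nc1n2[C@H]2OC[C@@H](O)[C@H]2OC1` a benzylamino group, and compound 4 `O=C1C(N2CCC2)=CC(=O)c2c1nc1n2[C@H]2OC[C@@H](O)[C@H]2OC1` an azetidin-1-yl group. In a functional assay on MCF7 cells (Homo sapiens) for inhibition, read by sulforhodamine B assay (on this read-out higher numbers stand for weaker inhibition and lower numbers for stronger inhibition), compound 1 gives 6580 nM. For compound 2 this assay reports only a limit, > 4000 nM (the limit of > 4000 nM in this assay, at which 1 of the 3 values shown sits). For compound 3 this assay likewise reports only a limit, > 8000 nM (the limit of > 8000 nM in this assay, at which 1 of the 3 values shown sits), so compound 3 stands at the weak end of what has been measured, with no exact number. The steps among the measured compounds give little to work with: an at least 1.2-fold higher number from compound 1 to compound 3 (0.08 log units; that floor lies within the scatter), while a step that the limit leaves unreadable from compound 1 to compound 2 and a step that the two limits leave unreadable from compound 2 to compound 3. The change to compound 4 is azetidin-1-yl in place of benzylamino on a double-bonded ring carbon. Within the data shown here, no measured step in this assay changes the substituent on that carbon to a group of this kind, so the expectation rests only on the weak activity of every measured compound. Compound 4 is estimated to stay weak, with a step that the limit leaves unreadable from compound 3 to compound 4 expected to lie within the scatter. For compound 4 the expected value in this assay is 15000 nM, with a range of 4000 nM to 60000 nM, and most likely only a limit will be reported.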

Compound 4, half-maximal inhibitory concentration: > 16000 nM
Compound 4 was reported as a limit (the forecaster's own chance of this, stated with the estimate: 70%); middle value at least 1.0-fold (0.02 log units) from the limit.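

In this assay compound 4 is reported only as a limit: the limit of > 16000 nM in this assay, at which 1 of the 4 values shown sits.

Against compound 1, the only compound in the series with an exact value, azetidin-1-yl in place of (2-methoxyphenyl)amino gives an at least 2.4-fold higher number from compound 1 to compound 4 (0.38 log units; beyond the scatter), the first step in the series to clear the scatter. It shows that on this double-bonded ring carbon a four-membered non-aromatic ring, carrying no aromatic ring and 0 hydrogen-bond donors, does not bring inhibition back into the range where the assay returns an exact number; the steps to compound 4 from compound 2 and from compound 3 cannot be read, with limits at both ends.

The aromatic ring and the amine hydrogen leave together in this change, so the compounds shown do not tell which of the two matters, if either does. An open-chain secondary amine such as ethylamino, or a morpholin-4-yl group on the same carbon, would begin to separate the two and would test whether any small amine gives an exact value.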